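Nitro for Hydroxy at a Cytotoxicity Limit

This account rests on a few compounds, and the source may have more. Where it says the series, first, only, none or still open, it means among the compounds named here.

Measured in an ADME assay on cells (Peritoneal macrophage, Mus musculus, strain BALB/c) for cytotoxicity, with a stated time of 72 h; a lower number here means that less compound is tolerated, a higher number that more compound is tolerated:
- Compound 1 `O=C(N/N=C/c1ccccc1O)c1ncccn1`: > 150000 nM, a limit
- Compound 2 `O=C(N/N=C/c1cc(O)ccc1O)c1ncccn1`: > 150000 nM, a limit
- Compound 3 `Cc1ccc(/C=N/NC(=O)c2ncccn2)c(O)c1`: > 150000 nM, a limit

Compound 2 stands at > 150000 nM, which is a limit of the assay and not a number. Its two companions also give only limits, so there is no exact value to start from. Compound 4 `O=C(N/N=C/c1cc([N+](=O)[O-])ccc1O)c1ncccn1` differs from compound 2 in one place: nitro in place of hydroxy on an aromatic carbon. In words, nitro takes the place of hydroxy on an aromatic carbon, para to a hydroxy group.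

Among the compounds with values here, two measured steps bear on this change. Hydroxy in place of hydrogen on an aromatic carbon gives a step that the two limits leave unreadable from compound 1 to compound 2. Methyl in place of hydrogen on an aromatic carbon gives a step that the two limits leave unreadable from compound 1 to compound 3. Neither size can be read, and neither step involves nitro. All the data show is the limit of > 150000 nM in this assay, at which 3 of the 3 values shown sit.

No step beyond the scatter is therefore expected in this assay, although any readable change could only be toward a lower number. The expected step is a number no higher from compound 2 to compound 4 (the limit leaves the size open). For compound 4 the estimated value is 150000 nM, with an expected range of 50000 nM to 300000 nM.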

Compound 4, half-maximal cytotoxic concentration: 63400 nM
Compound 4: middle estimate off by 2.4-fold (0.37 log units), on the high side, and the stated range covers the measured number.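

Until now, the carbon para to a hydroxy group had shown nothing, since hydrogen and hydroxy there both left the compound at the limit of this assay. Nitro in place of that hydroxy gives an at least 2.3-fold lower number from compound 2 to compound 4 (0.37 log units; beyond the scatter), and nitro in place of the hydrogen gives an at least 2.3-fold lower number from compound 1 to compound 4 (0.37 log units; beyond the scatter), so this position can carry a group that brings a readable fall in the tolerated concentration, whichever of the two groups it replaces. The earlier steps from compound 1 to compound 2 and to compound 3 cannot be read, which makes compound 4 the only compound here with an exact number and the only one whose change has a direction, set against a background where the other compounds all remain at the ceiling: the limit of > 150000 nM in this assay, at which 3 of the 4 values shown sit.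

Going by these compounds, how far compound 4 really lies from compound 1 and compound 2 stays open, since their limits fix only the smallest possible size of these steps. On these data alone, whether the lower number is particular to nitro is also open, as an amine, a carboxylic acid or a chlorine atom on the same carbon would be needed to tell.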